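Solubility of compound 3 and its methanesulfonamido counterpart

The source may report more compounds than this note shows. Statements on the series, on what has been measured and on what is new or still open speak of the compounds shown alone.

compound 1 `O=S(=O)(c1cccc(Nc2ccc3nccc(-c4ccncc4)c3n2)c1)N1CCCCC1`: 15000 nM
compound 2 `O=S(=O)(CCO)c1cccc(-c2ccc3nccc(-c4ccncc4)c3n2)c1`: 55000 nM
compound 3 `O=S(=O)(c1cccc(-c2ccc3nccc(-c4ccncc4)c3n2)c1)N1CCC(O)CC1`: 10000 nM

These three numbers come from a physicochemical assay for solubility, read by HPLC, using the shake flask method, measured as kinetic solubility, with a stated time of 20 h, at pH 6.5, tested at 200 uM (a lower number here means a less soluble compound, a higher number a more soluble compound), and frame the question of what compound 4 `CS(=O)(=O)Nc1cccc(-c2ccc3nccc(-c4ccncc4)c3n2)c1` will give. Compound 3, at 10000 nM, lies within the scatter of compound 1, which gives 15000 nM as its number. Compound 2 gives 55000 nM as the highest number of the three, and a 5.5-fold lower number from compound 2 to compound 3 (0.74 log units; beyond the scatter) is a modest step beyond the scatter.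

For the measured compounds named here, compound 4 carries methanesulfonamido in place of (4-hydroxypiperidin-1-yl)sulfonyl on an aromatic carbon as its one difference from compound 3. Going by the values given here, only one measured step bears on this change, the one above, where 4-hydroxypiperidin-1-yl took the place of 2-hydroxyethyl on a sulfonyl sulfur. Among the compounds with values here, that step is a loose guide, since it involved the same ring but a different replacement, and no measured compound here carries methanesulfonamido.

Within the data shown here, a modest rise is therefore expected, smaller than the one seen in that step, and the estimate is a 2.2-fold higher number from compound 3 to compound 4 (0.34 log units; beyond the scatter) as the likely size. The expected value for compound 4 in this assay is 22000 nM and the estimated range runs from 7000 nM to 70000 nM as a broad expectation.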

Compound 4, solubility: 20000 nM
For compound 4 the middle estimate is 1.1-fold (0.04 log units) above the measured one, and the stated range covers the measured number.
By their numbers in this assay, from the lowest: compounds 3, 1 and 4 (each within the scatter of the next); then compound 2.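

In this assay, placing methanesulfonamido on this aromatic carbon, meta to a large group, in place of (4-hydroxypiperidin-1-yl)sulfonyl gives a 2.0-fold higher number from compound 3 to compound 4 (0.30 log units; within the scatter), so the solubility read-out does not separate the group without a ring from the one carrying the six-membered non-aromatic ring. Set against (2-hydroxyethyl)sulfonyl at the same place, the change gives a 2.8-fold lower number from compound 2 to compound 4 (0.44 log units; beyond the scatter), which shows that of the three groups seen at this position, only (2-hydroxyethyl)sulfonyl stands apart from the others. No measurement at hand accounts for this difference.

The compounds shown leave open whether the hydroxyl of the 2-hydroxyethyl chain matters to this separation, which a plain ethyl group on the sulfonyl sulfur would test, and whether a longer chain ending in a hydroxyl would keep it. They also leave open how a carboxylic acid or an amine would read on this same aromatic carbon, with the rest of the compound unchanged.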